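Replacing methoxy with chloro on the aryl ring

The source may hold more compounds than are shown below. What is called first, only, known or untested is meant among the compounds shown, and "the series" means these compounds.

Of the compounds shown here, two carry numbers so far. Compound 1 `CC1(C)CC(=O)C2=C(C1)NC(=S)NC2c1ccccc1` gives 50% in a functional assay on the whole organism (strain Sprague-Dawley) with Rattus norvegicus as the target, read by paw edema, with stated times of 1 h and 4 h, at a dose of 70 mg/kg by the oral route; a lower number here means less inhibition, a higher number more inhibition at the dose given (going by the name of the read-out). Within the data shown here, compound 2 `COc1ccc(C2NC(=S)NC3=C2C(=O)CC(C)(C)C3)cc1` gives 71% in this assay, the higher of the two numbers, the single recorded step being a number 21 percentage points higher from compound 1 to compound 2 (beyond the scatter). Compound 3 `CC1(C)CC(=O)C2=C(C1)NC(=S)NC2c1ccc(Cl)cc1` is not yet measured. It differs from compound 2 by chloro in place of methoxy on an aromatic carbon. Among the measured compounds shown here, no measured step exchanges methoxy for chloro, so the step from compound 1 to compound 2 bears on it only indirectly: it shows that a group on that aromatic carbon moved the paw edema inhibition upward, but says nothing about chloro itself. Compound 3 is therefore expected to sit between the two measured numbers. The step of a number 9 percentage points lower from compound 2 to compound 3 (within the scatter) is expected to be small, quite possibly within the scatter. The estimate for compound 3 is 62%, within a range from 45% to 80%.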

Compound 3, a percentage reported as inhibition, in the whole organism at one dose (the size of the read-out at that dose, not a potency): 69%
For compound 3 the middle estimate is 7 percentage points below the measured one, and the stated range covers the measured number.
By their numbers in this assay, from the lowest: compound 1; then compounds 3 and 2 (each within the scatter of the next).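

In this assay, chloro in place of methoxy on the aromatic carbon para to a large group gives a number 2 percentage points lower from compound 2 to compound 3 (within the scatter), so the two groups cannot be told apart here, even though chloro has one heavy atom and no hydrogen-bond acceptor, while methoxy has two heavy atoms and one acceptor. Chloro in place of hydrogen at the same carbon gives a number 19 percentage points higher from compound 1 to compound 3 (beyond the scatter) alongside a number 21 percentage points higher from compound 1 to compound 2 (beyond the scatter), so the rise over hydrogen is no longer tied to methoxy alone, though this rests on these two groups only. Nothing at hand explains why the two groups match.

As far as these compounds go, whether an amine or a carboxylic acid at this aromatic carbon would keep the paw edema inhibition remains open. So does the effect of a longer chain such as ethoxy, or of chloro on another carbon of the ring.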